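The compounds below may be only part of what the source reports. "The series", "measured", "known", "first", "only" and "open" are said of these compounds alone.

Compound 1 `CC(C)N(Cc1cccc(OCCCCCC(=O)O)c1)C(=O)c1ccc(-c2cccc(N(C)C)c2)cc1` carries a dimethylamino group on the outer ring of a biaryl amide. In an ADME assay on BJ cells (Homo sapiens) for cytotoxicity, read by CellTiter-Glo and resazurin assay, with a stated time of 72 h (on this read-out higher numbers stand for an effect only at larger amounts of compound and lower numbers for an effect already at smaller amounts), compound 1 gives > 26000 nM, which is a limit of the assay rather than a number. Compound 2 `CC(C)N(Cc1cccc(OCCCCCC(=O)O)c1)C(=O)c1ccc(-c2ccncc2)cc1` replaces that ring with a pyridin-4-yl group; in this assay compound 2 gives > 26000 nM, again a limit. Compound 3 `CC(C)COc1cccc(-c2ccc(C(=O)N(Cc3cccc(OCCCCCC(=O)O)c3)C(C)C)cc2)c1` carries an isobutoxy group in the same position; in this assay compound 3 gives > 26000 nM, also a limit. The step from compound 1 to compound 3 is therefore a step that the two limits leave unreadable from compound 1 to compound 3, and the same holds for a step that the two limits leave unreadable from compound 1 to compound 2 and a step that the two limits leave unreadable from compound 2 to compound 3. All three values sit at one point, (the limit of > 26000 nM in this assay, at which 3 of the 3 values shown sit).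

Compound 4 `CC(C)Oc1cccc(-c2ccc(C(=O)N(Cc3cccc(OCCCCCC(=O)O)c3)C(C)C)cc2)c1` is not yet measured. It differs from compound 1 by isopropoxy in place of dimethylamino on an aromatic carbon. For the measured compounds named here, the nearest measured step is the one to compound 3, where isobutoxy in place of dimethylamino left the reading at the limit, so no movement beyond the scatter is expected from compound 1 to compound 4 in this assay, a step that the limit leaves unreadable from compound 1 to compound 4. Compound 4 is expected to give about 30000 nM, between 18000 nM and 70000 nM.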

Compound 4, half-maximal effective concentration: > 26000 nM
Compound 4: only a limit was reported; the forecaster's own chance of this, stated with the estimate: 85%; the middle value is on the limit's open side.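

Compound 4 also ends at a limit rather than a number, so its steps to compound 1, compound 2 and compound 3 cannot be read: the limit of > 26000 nM in this assay, at which 4 of the 4 values shown sit.

The compounds shown leave open how these four compare in this assay, and what concentration, if any, would reach the half-maximal effect.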